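A few compounds are considered here, and "the series" means these few. Any claim that something is new, unique, unknown or untested is made for them only; others in the source may bear on it.

Compound 1 `CC[C@H](C)[C@H](NC(=O)CN(c1ncnc2c1ncn2C1CCCCO1)C1CC1)C(=O)OCc1ccccc1` gives 20.4% in a functional assay on the whole organism (Tail, strain ICR) with Mus musculus as the target, in the tail flick test, with a stated time of 120 min, at a dose of 25 umol/kg by the oral route; on this read-out lower numbers stand for a weaker effect and higher numbers for a stronger effect at the one dose given. Compound 2 `O=C(CN(c1ncnc2c1ncn2C1CCCCO1)C1CC1)NCC(=O)OCc1ccccc1` gives 17.2%. Compound 3 `O=C(O)C[C@H](NC(=O)CN(c1nc(Cl)nc2[nH]cnc12)C1CC1)C(=O)O` gives 22%.

All three compounds share a core, and their three numbers sit close together. The number for compound 3 is the highest of the three, but its gap to compound 1 and its gap to compound 2 both lie within the scatter, so no real separation among them can be read from these values. Compound 4 `CC(C)[C@H](NC(=O)CN(c1nc(Cl)nc2[nH]cnc12)C1CC1)C(=O)O` has not yet been measured; it differs from compound 3 in a single place: isopropyl in place of carboxymethyl on a saturated chain carbon bound to an amide-type nitrogen and a carbonyl carbon.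

For the measured compounds named here, only one measured step bears on this change, the one at the same saturated chain carbon: a number 3.2 percentage points lower from compound 1 to compound 2 (within the scatter). That step swapped a sec-butyl for hydrogen, and it moved the read-out only within the scatter. Going by the values given here, nothing among the measured compounds suggests that what sits on this chain carbon shifts the read-out by more than the scatter, though one step is thin ground. The step from compound 3 to compound 4 is therefore expected to be small, a number 2 percentage points lower from compound 3 to compound 4 (within the scatter), with no direction that can be trusted. Compound 4 is estimated at 20%, most likely between 10% and 30%.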

Compound 4, a percentage reported as activity, at one dose (the size of the read-out at that dose, not a potency): 17.1%
Compound 4: the middle estimate sits 2.9 percentage points above what was measured, within the range that was stated.
By their numbers in this assay, from the lowest: compounds 4, 2, 1 and 3 (each within the scatter of the next).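

In this assay, isopropyl in place of carboxymethyl on the saturated chain carbon bound to an amide-type nitrogen and a carbonyl carbon gives a number 4.9 percentage points lower from compound 3 to compound 4 (within the scatter), so exchanging a group with a carboxylic acid for a purely carbon group of similar size leaves no separation that can be read. This is new: the earlier step at this carbon, a number 3.2 percentage points lower from compound 1 to compound 2 (within the scatter), only compared sec-butyl with hydrogen, whereas here the group that leaves carries a hydrogen-bond donor and a hydrogen-bond acceptor and the group that enters carries neither. Both steps at this carbon now stay within the scatter, one on the core of compound 1 and one on the core of compound 3, and no compound shown goes against this, but no information is available on why the read-out stays put.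

Going by these compounds, whether an amine or a longer chain on this carbon would move the read-out beyond the scatter remains open. Also open is whether these small steps would hold at another dose or another time, since only one dose and one time are shown.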